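This account rests on a few compounds, and the source may have more. Where it says the series, first, only, none or still open, it means among the compounds named here.

Working notes on a small set of substituted six-membered aromatic cores carrying a hydroxy group, read in a functional assay on cells (Lymphocyte, Homo sapiens), read by a luciferase reporter and ATP content, with a stated time of 48 h, tested at 1 uM; a lower number here means a stronger effect, a higher number a weaker effect of the compound at the concentration tested.

Compound 1 `Cc1nc(OC2CCC2)nc(N2CCC2)c1O` gives 101% in this assay. Compound 2 `CCCCCCCCCCCCCCCCc1nc(OC2CCC2)nc(N2CCC2)c1O` carries a long chain where compound 1 carries a methyl group; in this assay compound 2 gives 102%. Compound 3 `CCCCCCCCCCCCCCCCc1nc(OC2CCC2)nc(OC2CCC2)c1O`, which carries two cyclobutyloxy groups, gives 98% in this assay. All three numbers sit close together and none of the gaps between them stands out from the usual spread of repeated runs. The difference between the core of compound 1 and the core of compound 3 is not broken down here.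

One structural change has been measured within this set: azetidin-1-yl in place of cyclobutyloxy on an aromatic carbon. It produced a number 4 percentage points higher from compound 3 to compound 2 (within the scatter).

Compound 4 `Cc1nc(N2CCC2)nc(N2CCC2)c1O` has not been measured. It is the same kind of change applied to compound 1: azetidin-1-yl in place of cyclobutyloxy on an aromatic carbon. The surroundings of the changed carbon are not the same as in the measured pair: in compound 1 the leaving group sits between two ring nitrogen atoms, meta to a methyl group, meta to an azetidin-1-yl group and para to a hydroxy group, whereas in compound 3 it sits next to the ring nitrogen, ortho to a hydroxy group, meta to a cyclobutyloxy group, meta to a large group and opposite the ring nitrogen.

Among the compounds with values here, the expected step from compound 1 is a number 1 percentage points lower from compound 1 to compound 4 (within the scatter), because the only measured example of this kind of change, a number 4 percentage points higher from compound 3 to compound 2 (within the scatter), stayed within the spread, and because every compound here, including compound 1 at 101%, reads near the unaffected level.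

On that basis compound 4 is estimated at 100% in this assay, with an expected range from 88% to 112%.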

Compound 4, a percentage reported as activity, at one concentration (the size of the read-out at that concentration, not a potency): 101%
Beside the measured number, compound 4's estimate is 1 percentage points below it; the range from low to high includes it.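

In this assay, azetidin-1-yl in place of cyclobutyloxy on an aromatic carbon gave no change at the digits printed from compound 1 to compound 4 (within the scatter). Set beside the earlier step, the change reads alike on the two cores: the same change on two cores in this assay, a number 4 percentage points higher (within the scatter) from compound 3 to compound 2 and no change at the digits printed (within the scatter) from compound 1 to compound 4, 4 percentage points apart, within the scatter of two such steps. Within the data shown here, this shows only that the change left no readable mark on either core at the single concentration tested; since none of the compounds on either side of these two steps moves clearly away from the unaffected level, the agreement says nothing about whether the change would carry over to a core that shows a real effect, and it gives no potency for any compound.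

The compounds shown have only cyclobutyloxy or azetidin-1-yl on that aromatic carbon, and only a methyl group or a long chain as the other varied substituent, so it remains open whether a larger cyclic amine such as piperidin-1-yl, an open-chain amine such as dimethylamino, or a carboxylic acid would give a reading apart from this cluster. Also open, as far as these compounds go, is whether a chain of intermediate length, such as hexyl, would read any differently from the methyl group and the long chain.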